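Changing the group on the amide nitrogen of compound 2

A few compounds are considered here, and "the series" means these few. Any claim that something is new, unique, unknown or untested is made for them only; others in the source may bear on it.

In an ADME assay on MT4 cells (Homo sapiens) for cytotoxicity, read by MTT assay, with a stated time of 5 days (a higher number here means that more compound is tolerated, a lower number that less compound is tolerated), compound 1 `Cc1cc(C)cc(S(=O)(=O)c2c(C(=O)N[C@@H]3CCN(CC(N)=O)C3)[nH]c3ccc(Cl)cc23)c1` gives 31000 nM. Compound 2 `Cc1cc(C)cc(S(=O)(=O)c2c(C(=O)N[C@H]3CCN(CC(N)=O)C3)[nH]c3ccc(Cl)cc23)c1` gives 28100 nM, which places it level with compound 1 within the scatter. Compound 3 `Cc1cc(C)cc(S(=O)(=O)c2c(C(=O)NC3CN(S(C)(=O)=O)C3)[nH]c3ccc(Cl)cc23)c1` keeps the shared core but carries 1-(methylsulfonyl)azetidin-3-yl in place of 1-(carbamoylmethyl)pyrrolidin-3-yl on an amide-type nitrogen. The entering group has no defined stereocentre, whereas the leaving group has one.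

For the measured compounds named here, only one measured step bears on this change, and it does so indirectly. That step is a 1.1-fold lower number from compound 1 to compound 2 (0.04 log units; within the scatter), and it comes with the fact that compounds 1 and 2 differ only in the configuration as drawn. It shows that inverting the stereocentre of the leaving group moved the number by no more than the scatter. Going by the values given here, no measured step replaces the group itself, so the evidence is thin and the range must stay wide. With compound 2 as the starting point at 28100 nM, no step beyond the scatter is expected in this assay, in either direction. The expected change is a 1.1-fold lower number from compound 2 to compound 3 (0.05 log units; within the scatter). Compound 3 is estimated at 25000 nM, with an expected range of 9000 nM to 60000 nM.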

Compound 3, half-maximal cytotoxic concentration: > 252000 nM
Compound 3 ended at the assay's limit; the forecaster's own chance of this, stated with the estimate: 15%; middle value at least 10-fold (1.00 log units) away from the limit.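

Read alone, the earlier compounds showed only that in this assay the drawn configuration of the group on the amide nitrogen left the number within the scatter, and that comparison rested on one narrow contrast: the fact that compounds 1 and 2 differ only in the configuration as drawn. Replacing the whole group with 1-(methylsulfonyl)azetidin-3-yl shows that this position can move the number beyond the scatter, with an at least 8.9-fold higher number from compound 2 to compound 3 (0.95 log units; beyond the scatter) and an at least 8.1-fold higher number from compound 1 to compound 3 (0.91 log units; beyond the scatter), so the result holds against both configurations of the leaving group. For compound 3, > 252000 nM is a limit of the assay and not a number, so both steps give only a minimum size: the limit of > 252000 nM in this assay, at which 1 of the 3 values shown sits.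

The change swaps a five-membered ring for a four-membered one, replaces carbamoylmethyl with methylsulfonyl on the ring nitrogen and removes the stereocentre all at once, and the compounds shown cannot separate these parts. From the compounds shown here alone, it therefore remains open whether 1-(methylsulfonyl)pyrrolidin-3-yl, which keeps the five-membered ring, or 1-(carbamoylmethyl)azetidin-3-yl, which keeps the carbamoylmethyl group, would stand nearer to compound 2 or to compound 3.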